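The source may report more compounds than this note shows. Statements on the series, on what has been measured and on what is new or still open speak of the compounds shown alone.

In a toxicity assay on THP-1 cells (Homo sapiens) for inhibition (on this read-out higher numbers stand for lower toxicity in this test and lower numbers for higher toxicity in this test), compound 3 `COc1ccc(-c2cnc(NC(=O)c3ccc(F)cc3)n2C)cc1` gives >= 50000 nM, which is a limit of the test rather than a number. Compound 1 `COc1ccc(-c2cnc(NC(=O)c3cnc[nH]3)n2C)cc1` gives > 100000 nM in this assay, again only a limit. Compound 2 `COc1ccc(-c2cnc(NC(=O)CCc3ccccc3)n2C)cc1` likewise reaches only a limit in this assay, at > 100000 nM. Because every value sits at a limit, as the limit of > 100000 nM in this assay, at which 2 of the 3 values shown sit, and the limit of >= 50000 nM in this assay, at which 1 of the 3 values shown sits, show, none of the three steps is readable: the step that the two limits leave unreadable from compound 1 to compound 2, the step that the two limits leave unreadable from compound 1 to compound 3 and the step that the two limits leave unreadable from compound 2 to compound 3 all change the group on the carbonyl carbon without yielding a measurable size in this assay.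

Compound 4 `COc1ccc(-c2cnc(NC(=O)c3ccncc3)n2C)cc1` differs from compound 3 in one place: pyridin-4-yl in place of 4-fluorophenyl on a carbonyl carbon. Among the compounds with values here, no measured step bears readably on this change; the three earlier swaps at the same carbonyl carbon left toxicity at or beyond the limits in every case. Compound 4 is therefore expected to give about 100000 nM in this assay, within 50000 nM to 200000 nM. The step that the limit leaves unreadable from compound 3 to compound 4 is expected to lie within the scatter, most likely returning only a limit again.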

Compound 4, half-maximal cytotoxic concentration: > 100000 nM
Compound 4: only a limit was reported (the forecaster's own chance of this, stated with the estimate: 85%); the middle value sits exactly at the limit.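

Compound 4 adds no readable step in this assay: its comparisons with compound 1, compound 2 and compound 3 all rest on limits rather than numbers. The compounds shown leave open whether any of these groups on the carbonyl carbon changes toxicity in this assay, and by how much.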